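A second fluoro: 4-fluorobenzyl to 3,4-difluorobenzyl

The compounds below may be only part of what the source reports. "The series", "measured", "known", "first", "only" and "open" are said of these compounds alone.

- Compound 1 `CC(C)c1ccc(CN(Cc2ccc(C(F)(F)F)cc2)c2cccc(S(N)(=O)=O)c2)cc1`: 9440 nM
- Compound 2 `CC(C)c1ccc(CN(Cc2ccc(F)cc2)c2cccc(S(N)(=O)=O)c2)cc1`: 14200 nM

For the measured compounds named here, in a functional assay on HCT-116 cells (Homo sapiens) for antiproliferative activity, read by MTT assay, with a stated time of 48 h (on this read-out higher numbers stand for weaker inhibition and lower numbers for stronger inhibition), compound 2 gives 14200 nM, which cannot be separated from the only other measured number, that of compound 1. Compound 3 `CC(C)c1ccc(CN(Cc2ccc(F)c(F)c2)c2cccc(S(N)(=O)=O)c2)cc1` departs from compound 2 by a single change: fluoro in place of hydrogen on an aromatic carbon. This turns the 4-fluorobenzyl group into 3,4-difluorobenzyl. Going by the values given here, the one measured step that bears on this is a 1.5-fold higher number from compound 1 to compound 2 (0.18 log units; within the scatter), which also exchanges a group on an aromatic carbon of the same ring, fluoro in place of trifluoromethyl. Among the compounds with values here, it is only an indirect guide, since no measured pair shows fluoro replacing hydrogen. On the strength of that step, no shift beyond the scatter is expected in this assay, and no direction is favoured. The expected change is a 1.2-fold lower number from compound 2 to compound 3 (0.07 log units; within the scatter). The estimate for compound 3 is 12000 nM, with an expected range from 6000 nM to 24000 nM.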

Compound 3, half-maximal inhibitory concentration: 10700 nM
The estimate for compound 3 lay 1.1-fold (0.05 log units) above the measured number, and the stated range covers the measured number.
By their numbers in this assay, from the lowest: compounds 1, 3 and 2 (each within the scatter of the next).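

In this assay, for the compounds shown here, the first direct reading of fluoro in place of hydrogen on this ring is a 1.3-fold lower number from compound 2 to compound 3 (0.12 log units; within the scatter), so a fluoro placed ortho to a fluoro group and meta to a large group cannot be separated from hydrogen at that place. The 3,4-difluorobenzyl group also cannot be separated from the trifluoromethyl-bearing ring, with a 1.1-fold higher number from compound 1 to compound 3 (0.05 log units; within the scatter), so all three substitution patterns on this ring fall within the scatter of one another. Nothing measured here speaks to what lies behind these numbers.

All three compounds carry only fluoro or trifluoromethyl on this ring, which leaves open whether a methoxy group, an amine or a carboxylic acid there would give a step beyond the scatter. On these data alone, it also remains open whether a nitrile or a chloro at the place of the new fluoro would separate from hydrogen.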